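A few compounds are considered here, and "the series" means these few. Any claim that something is new, unique, unknown or untested is made for them only; others in the source may bear on it.

Of the compounds shown here, three of a shared core have been tested in a functional assay on MCF7 cells (Homo sapiens) for inhibition, read by sulforhodamine B assay, with a stated time of 72 h; a higher number here means a weaker inhibitor, a lower number a stronger inhibitor. Compound 1 `COc1ccc2cc(C(C)c3nnc4n3N=C(c3ccc(C)cc3)CS4)ccc2c1` gives 11000 nM in this assay. Compound 2 `CC(C)Cc1ccc(C(C)c2nnc3n2N=C(c2ccccc2)CS3)cc1` gives 9700 nM in this assay, and compound 3 `CC(c1ccc(-c2ccccc2)c(F)c1)c1nnc2n1N=C(c1ccc(F)cc1)CS2` gives 8100 nM in this assay; all three values lie within the usual scatter of one another, so none of them can be set apart from the others. A fourth compound, compound 4 `COc1ccc2cc(C(C)c3nnc4n3N=C(c3ccc(Cl)cc3)CS4)ccc2c1`, has not yet been measured. Going by the values given here, it differs from compound 1 by a single change, (chloro in place of methyl on an aromatic carbon), a step for which no measured pair of compounds exists here. With nothing in the measured set to suggest a shift, compound 4 is expected to remain close to compound 1, with an estimated step of a 1.2-fold lower number from compound 1 to compound 4 (0.09 log units; within the scatter). Compound 4 is therefore estimated at 9000 nM in this assay, within a range from 4000 nM to 25000 nM.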

Compound 4, half-maximal inhibitory concentration: 10100 nM
Beside the measured number, compound 4's estimate is 1.1-fold (0.05 log units) below it, within the range that was stated.
By their numbers in this assay, from the lowest: compounds 3, 2, 4 and 1 (each within the scatter of the next).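

Going by these compounds alone, the pair of compound 1 and compound 4 gives the first comparison in this set that turns on a single place. On the aromatic carbon para to a large group, chloro in place of methyl gives a 1.1-fold lower number from compound 1 to compound 4 (0.04 log units; within the scatter) in this assay, so the 4-methylphenyl and 4-chlorophenyl compounds cannot be told apart here. No supporting data bear on this result. The compounds shown leave open whether an amine or a carboxylic acid on this carbon would give a step beyond the scatter.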